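The source may hold more compounds than are shown below. What is called first, only, known or untested is meant among the compounds shown, and "the series" means these compounds.

Compound 1 `O=C(Cn1c(=O)oc2cc(Cl)ccc21)NCc1ccco1` and compound 2 `O=C(Cn1c(=O)oc2cc(Cl)ccc21)Nc1nc2ccc([N+](=O)[O-])cc2s1` carry the same chloro-bearing bicyclic core but differ on the amide side; the difference between the two is not broken down here. Compound 3 `O=C(Cn1c(=O)oc2cc([N+](=O)[O-])ccc21)Nc1nc2ccc([N+](=O)[O-])cc2s1` repeats the amide side of compound 2 with a change on the core: nitro in place of chloro on an aromatic carbon.

In an ADME assay on RAW264.7 cells (Mus musculus) for cytotoxicity, read by MTT assay, with a stated time of 72 h, tested at 100 uM (on this read-out higher numbers stand for a stronger effect at the one concentration tested and lower numbers for a weaker effect), compound 1 gives 50.3%. Compound 2 gives 14.2% in this assay, and compound 3 gives 39%. Going by the values given here, the one single-site step that is measured runs a number 24.8 percentage points higher from compound 2 to compound 3 (beyond the scatter). Compound 1 stands highest of the three numbers, beyond the scatter against both compound 3 and compound 2.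

Compound 4 `O=C(Cn1c(=O)oc2cc([N+](=O)[O-])ccc21)NCc1ccco1` is not yet measured. It relates to compound 1 as compound 3 relates to compound 2: nitro in place of chloro on an aromatic carbon. The place lines agree word for word, so this is the same change, made a second time, now on the furan-bearing amide side rather than the nitro-benzothiazole side.

For compound 4 the expectation rests on two things: the step of a number 24.8 percentage points higher from compound 2 to compound 3 (beyond the scatter) on the other amide side, and the starting point of compound 1 at 50.3%, which already stands high so that an equally large rise may be compressed. The step from compound 1 to compound 4 is therefore estimated at a number 17.7 percentage points higher from compound 1 to compound 4 (beyond the scatter), somewhat smaller than the measured one. Compound 4 is expected to give about 68% in this assay, with a plausible range from 50% to 86%.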

Compound 4, a percentage reported as inhibition, at one concentration (the size of the read-out at that concentration, not a potency): 60.1%
For compound 4 the middle estimate is 7.9 percentage points above the measured one, and the stated range covers the measured number.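

In this assay, nitro in place of chloro on an aromatic carbon of the shared core gives a number 9.8 percentage points higher from compound 1 to compound 4 (within the scatter), so on the furan-bearing amide side this step cannot be told apart from repeat scatter. The same change therefore does not carry over with a fixed size from one amide side to the other, as the two steps differ: the same change on two cores in this assay, a number 24.8 percentage points higher (beyond the scatter) from compound 2 to compound 3 and a number 9.8 percentage points higher (within the scatter) from compound 1 to compound 4, 15 percentage points apart, beyond the scatter of two such steps

Going by these compounds alone, this does not show why the two steps differ, whether through the amide side itself or through the starting value of each pair, and with only two pairs, one of them within the scatter, it gives neither a general rule for this change nor a firm direction for it across the series.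

The compounds shown leave open how a nitrile or an amine on the same aromatic carbon would read in this assay, and how the chloro and nitro pair would behave on an amide side carrying a longer alkyl chain or a carboxylic acid. They also leave open how these compounds compare across a range of concentrations, as each number here comes from one concentration and is not a potency.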